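Adding fluoro to compound 2: an expected small step

This account rests on a few compounds, and the source may have more. Where it says the series, first, only, none or still open, it means among the compounds named here.

Compound 1 `O=S(=O)(c1ccccc1)c1nc2ccccc2nc1N1CCCC1` gives 3460 nM
Compound 2 `O=S(=O)(c1ccccc1)c1nc2ccccc2nc1N1CCCC(O)C1` gives 3020 nM

In a functional assay on HL-60 cells (Homo sapiens) for cytotoxicity, read by MTT assay, with a stated time of 72 h (a higher number here means a weaker inhibitor, a lower number a stronger inhibitor), compound 2, at 3020 nM, stands level with compound 1 within the scatter. Compound 3 `O=S(=O)(c1ccc(F)cc1)c1nc2ccccc2nc1N1CCCC(O)C1` differs from it by fluoro in place of hydrogen on an aromatic carbon, which turns phenyl into 4-fluorophenyl. Among the compounds with values here, the only measured step, a 1.1-fold lower number from compound 1 to compound 2 (0.06 log units; within the scatter), concerns a different group and stays within the scatter. Within the data shown here, no measured step shows this change, so no shift beyond the scatter is expected. The expected step is a 1.1-fold lower number from compound 2 to compound 3 (0.03 log units; within the scatter). For compound 3 the estimated value is 2800 nM, with an expected range of 1300 nM to 5500 nM.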

Compound 3, half-maximal inhibitory concentration: 2620 nM
Compound 3: the middle estimate sits 1.1-fold (0.03 log units) above what was measured, and the stated range covers the measured number.
By their numbers in this assay, from the lowest: compounds 3, 2 and 1 (each within the scatter of the next).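

In this assay the change from phenyl to 4-fluorophenyl gives a 1.2-fold lower number from compound 2 to compound 3 (0.06 log units; within the scatter) and is the first step shown at this position of the shared core. Fluoro on this aromatic carbon, para to a large group, therefore leaves the number level with that of compound 2. Nothing available accounts for this result. Going by these compounds, whether methoxy, an amine or a carboxylic acid on this same carbon would move the number beyond the scatter stays open. So does whether fluoro would behave alike with pyrrolidin-1-yl in place of 3-hydroxypiperidin-1-yl.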